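Solubility of two cyclopropyl amides on two related cores

The source may hold more compounds than are shown below. What is called first, only, known or untested is meant among the compounds shown, and "the series" means these compounds.

Compound 1, `CNC(=O)c1cc(C(=O)N[C@H]2[C@@H]3COC[C@@H]32)cc2c1OC[C@@]2(C)c1ccccc1`, in a physicochemical assay for solubility (on this read-out lower numbers stand for lower solubility and higher numbers for higher solubility), gives >= 147 ug/mL, which is a limit of the assay and not a number.
Compound 2, `CNC(=O)c1cc(C(=O)NC2CC2)cc2c1OC[C@@]2(C)c1ccccc1`, in this assay gives >= 138 ug/mL, again a limit of the assay.
Compound 3, `CNC(=O)c1cc(C(=O)N[C@H]2[C@@H]3COC[C@@H]32)cc2c1OC[C@H]2c1ccc(F)cc1`, in this assay gives >= 176 ug/mL, also a limit of the assay.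

All three measured values sit at limits (the limit of >= 138 ug/mL in this assay, at which 1 of the 3 values shown sits, (the limit of >= 147 ug/mL in this assay, at which 1 of the 3 values shown sits), (the limit of >= 176 ug/mL in this assay, at which 1 of the 3 values shown sits)), so none of them is a number that can be compared with another. The change from compound 1 to compound 2 is a group of 3 heavy atoms (3 carbon; one three-membered non-aromatic ring of carbon only) in place of a group of 6 heavy atoms (5 carbon, 1 oxygen; one three-membered non-aromatic ring of carbon only, one five-membered non-aromatic ring with 1 hetero atom), on an amide-type nitrogen. Its effect, a step that the two limits leave unreadable from compound 1 to compound 2, cannot be read because both ends are limits. The unmeasured compound 4, `CNC(=O)c1cc(C(=O)NC2CC2)cc2c1OC[C@H]2c1ccc(F)cc1`, carries the same change on the core of compound 3: a group of 3 heavy atoms (3 carbon; one three-membered non-aromatic ring of carbon only) in place of a group of 6 heavy atoms (5 carbon, 1 oxygen; one three-membered non-aromatic ring of carbon only, one five-membered non-aromatic ring with 1 hetero atom), on an amide-type nitrogen. How the core of compound 3 differs from that of compound 1 is not broken down here. Since every measured compound, including compound 3 with >= 176 ug/mL, reached a limit, compound 4 is expected to do the same, with an expected step of an at least 1.1-fold lower number from compound 3 to compound 4 (0.04 log units; that floor lies within the scatter). The estimate for compound 4 in this assay is therefore 160 ug/mL, with a range from 90 ug/mL to 300 ug/mL.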

Compound 4, solubility: 40 ug/mL
Compound 4: the middle estimate sits 4.0-fold (0.60 log units) above what was measured, and the stated range ends above it.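

In this assay, putting cyclopropyl in place of the group of 6 heavy atoms on the amide-type nitrogen gives an at least 4.4-fold lower number from compound 3 to compound 4 (0.64 log units; beyond the scatter). That size is only a floor, as the value of compound 3 is a limit of the assay and not a number: the limit of >= 176 ug/mL in this assay, at which 1 of the 4 values shown sits. The same change on the core of compound 1 cannot be read, with a limit at both of its ends, so the data show that this change can come with a clear fall on one core, but not that the fall carries over to the other core, nor that it would recur on any further core.

The compounds shown leave open how other groups on the amide-type nitrogen would read on these two cores, for example a longer chain such as n-butyl or a group carrying an amine. Also open, on these data alone, is the true size of the step on either core, and whether the two cores would agree once numbers rather than limits stand at each end.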